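The source may report more compounds than this note shows. Statements on the series, on what has been measured and on what is new or still open speak of the compounds shown alone.

Compound 1 `CCC(/C=C(\COC(=O)c1ccccc1)C(=O)c1ccc(OC)cc1)CC`: > 100000 nM (a limit)
Compound 2 `COc1ccc(C(=O)/C(=C/C2CCCCC2)COC(=O)c2ccccc2)cc1`: 36000 nM

Both compounds were tested in a functional assay on A549 cells (Homo sapiens) for inhibition, read by XTT assay, with a stated time of 48 h; on this read-out higher numbers stand for weaker inhibition and lower numbers for stronger inhibition. The entry for compound 1 is a limit of the assay, not a number. Among the compounds with values here, compound 2, at 36000 nM, therefore holds the only true number so far. Within the data shown here, the one measured step, an at least 2.7-fold lower number from compound 1 to compound 2 (0.44 log units; beyond the scatter), swapped a different group, so it offers little guidance here. Compound 3 `COc1ccc(C(=O)/C(=C/C2CCCCC2)CC(C)OC(C)=O)cc1` keeps the cyclohexyl but carries 1-acetoxyethyl in place of benzoyloxy on a saturated chain carbon bound to a double-bonded chain carbon. Among the measured compounds shown here, with no measured step at this place, the expected change is none beyond the scatter: a 1.3-fold higher number from compound 2 to compound 3 (0.10 log units; within the scatter). Compound 3 is estimated at 45000 nM, with an expected range of 15000 nM to 100000 nM.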

Compound 3, half-maximal inhibitory concentration: 98000 nM
Estimate against measurement, compound 3: 2.2-fold (0.34 log units) below, and the stated range covers the measured number.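

Within this assay putting 1-acetoxyethyl in place of benzoyloxy gives a 2.7-fold higher number from compound 2 to compound 3 (0.43 log units; beyond the scatter) and so shows for the first time that this place, a saturated chain carbon bound to a double-bonded chain carbon, matters for the read-out. Of this pair, compound 2 with its benzoyloxy group gives the stronger inhibition. Compound 3 leaves little room on this scale before the assay stops giving a number: the limit of > 100000 nM in this assay, at which 1 of the 3 values shown sits.

The compounds shown leave open whether the loss of the aromatic ring or some other part of the change accounts for this step. Going by these compounds, how an amine or a carboxylic acid would behave at this place also remains open.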